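The source may hold more compounds than are shown below. What is called first, only, known or untested is meant among the compounds shown, and "the series" means these compounds.

Values so far in a functional assay on ileum (Cavia porcellus) for antagonist activity; on this read-out lower numbers stand for stronger inhibition and higher numbers for weaker inhibition

compound 1 `CCc1cc2c(O)c([N+](=O)[O-])c(=O)oc2cc1OCCCOc1ccccc1` gives > 10000 nM as a limit
compound 2 `CC(=O)c1ccc(OCCCOc2ccc3c(O)c([N+](=O)[O-])c(=O)oc3c2)cc1` gives 6100 nM as a number

For compound 1 the reading > 10000 nM is a limit of the assay and not a number. Within the data shown here, compound 2 with 6100 nM is the only compound so far that has an actual number in this assay on the scale.

Compound 3 `Cc1ccccc1OCCCOc1ccc2c(O)c([N+](=O)[O-])c(=O)oc2c1` has not yet been measured. It keeps the shared core of compound 2 and carries 2-methylphenyl in place of 4-acetylphenyl on an oxygen on a saturated carbon, a change counted as 2-methylphenyl in place of 4-acetylphenyl on an oxygen on a saturated carbon in full.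

Among the measured compounds shown here, no measured pair of compounds differing in one place is available, so the size of this exchange cannot be read directly from the data. The expectation rests on compound 2 with 6100 nM as its only anchor, and it is for a modest loss of inhibition, little beyond the scatter. The estimate amounts to a 1.3-fold higher number from compound 2 to compound 3 (0.12 log units; within the scatter) as the expected step. For compound 3 the expected value is 8000 nM with an estimated range from 2500 nM to 25000 nM in this measurement.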

Compound 3, half-maximal inhibitory concentration: 590 nM
Beside the measured number, compound 3's estimate is 14-fold (1.13 log units) above it, and the stated range ends above it.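

In this assay, among these compounds, placing 2-methylphenyl in place of 4-acetylphenyl on an oxygen on a saturated carbon gives a 10-fold lower number from compound 2 to compound 3 (1.01 log units; beyond the scatter), the first step that can be read between two measured compounds differing in one place. It shows that inhibition in this read-out responds strongly to what this position carries, even though the six-membered aromatic ring of carbon stays and only the group on that ring and its place on the ring change. Nothing in the data given accounts for the size of this step.

Among the compounds shown here, the single step leaves open whether it follows from the arrival of the methyl group, the loss of the acetyl group or the different place on the ring, and a 4-methylphenyl group at this position would be needed to begin separating these. As far as these compounds go, how far the trend extends in this assay also remains open, including whether an amine, a carboxylic acid or a longer chain on this ring would keep or lose the lower number of compound 3.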